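Replacing the Trimethoxyphenyl Group of Compound 2

This account rests on a few compounds, and the source may have more. Where it says the series, first, only, none or still open, it means among the compounds named here.

Measured compounds:
compound 1, `Cn1ncnc1-c1cc(Oc2ccc(NC(=O)N/N=C/c3ccccc3)cc2F)ccn1`, 30200 nM
compound 2, `COc1cc(/C=N/NC(=O)Nc2ccc(Oc3ccnc(-c4nncn4CCN(C)C)c3)c(F)c2)cc(OC)c1OC`, 3620 nM
compound 3, `Cn1cnnc1-c1cc(Oc2ccc(NC(=O)N/N=C/c3ccccc3)cc2F)ccn1`, 8790 nM

In a functional assay on HT-29 cells (Homo sapiens) for cytotoxicity, read by MTT assay, with a stated time of 72 h (a higher number here means a weaker inhibitor, a lower number a stronger inhibitor), compound 2 gives the lowest number of the three, and its gaps to compound 3 and to compound 1 both lie beyond the usual scatter, so compound 2 is the strongest inhibitor among those measured. Compound 4, `Cc1cc(/C=N/NC(=O)Nc2ccc(Oc3ccnc(-c4nncn4CCN(C)C)c3)c(F)c2)cc(C)c1O`, differs from compound 2 in one place: 4-hydroxy-3,5-dimethylphenyl in place of 3,4,5-trimethoxyphenyl on a carbon with a double bond to nitrogen.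

Among the measured compounds shown here, only one measured step exists, a 3.4-fold lower number from compound 1 to compound 3 (0.54 log units; beyond the scatter), and it concerns a different part of the shared core, not the group on the carbon with a double bond to nitrogen. For the measured compounds named here, no measured pair alters that group, so the data give no indication of direction for this change. The step of a 1.2-fold higher number from compound 2 to compound 4 (0.09 log units; within the scatter) is therefore expected to stay within the scatter. Compound 4 is estimated at 4500 nM in this assay, with a range from 1500 nM to 14000 nM.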

Compound 4, half-maximal inhibitory concentration: 1220 nM
For compound 4 the middle estimate is 3.7-fold (0.57 log units) above the measured one; the whole stated range lies above it.
By their numbers in this assay, from the lowest: compound 4; then compound 2; then compound 3; then compound 1.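

In this assay, among the compounds shown here, the group on a carbon with a double bond to nitrogen proves able to move the number: the step of a 3.0-fold lower number from compound 2 to compound 4 (0.47 log units; beyond the scatter) is the first measured change at this place, with the rest of compound 2 kept intact. The group that enters, 4-hydroxy-3,5-dimethylphenyl, has fewer heavy atoms than 3,4,5-trimethoxyphenyl and carries a hydrogen-bond donor that the group it replaces lacks, so a smaller group with a donor is tolerated here. Nothing on hand explains why this exchange lowers the number.

The compounds shown leave open whether the hydroxy group or the two methyl groups account for the step, as the two are not varied apart. They also leave open how an amine or a carboxylic acid on this phenyl ring would compare.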